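Hydroxamic acid series: aryl-substituted compounds in PC-3 growth inhibition

The source may report more compounds than this note shows. Statements on the series, on what has been measured and on what is new or still open speak of the compounds shown alone.

Measured compounds:
compound 1 `CCOc1ccc(CCCN2CC=C(CCC(=O)NO)C2=O)cc1` gives 3480 nM in a functional assay on PC-3 cells (Homo sapiens) for inhibition, read by sulforhodamine B assay; a lower number here means a stronger inhibitor of growth, a higher number a weaker inhibitor of growth.
compound 2 `O=C(CCC1=CCN(Cc2cccc(Br)c2)C1=O)NO` gives 4620 nM in this assay.
compound 3 `O=C(CCC1=CCN(Cc2ccc(Br)cc2F)C1=O)NO` gives 4620 nM in this assay.

Compound 1 has the lowest of the three numbers in this assay, yet its gap to compound 2 and to compound 3 lies within the usual scatter, so no ranking can be drawn among the three. Among the compounds with values here, no step between measured compounds that differ in one place is available.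

Compound 4 `CC(C)c1ccc(CCCN2CC=C(CCC(=O)NO)C2=O)cc1` is not yet measured. It differs from compound 1 as follows: isopropyl in place of ethoxy on an aromatic carbon. Within the data shown here, no measured pair in this set informs on such an exchange at this place. The step from compound 1 to compound 4 in this assay is therefore expected to be small, with no direction beyond the scatter: a 1.2-fold lower number from compound 1 to compound 4 (0.06 log units; within the scatter). For compound 4 a value of 3000 nM is estimated, with a range from 1200 nM to 8000 nM.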

Compound 4, concentration for 50% growth inhibition: 3480 nM
For compound 4 the middle estimate is 1.2-fold (0.06 log units) below the measured one; measured number inside the range.
By their numbers in this assay, from the lowest: compounds 1, 4, 2 and 3 (each within the scatter of the next).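

In this assay, isopropyl in place of ethoxy on the aromatic carbon para to a large group gives no change at the digits printed from compound 1 to compound 4 (within the scatter), the first step read at this place. The exchange removes the one hydrogen-bond acceptor of ethoxy and keeps the count of heavy atoms, and the number does not respond. No measurement available here bears on the reason for this. As far as these compounds go, whether an amine or a carboxylic acid on this aromatic carbon would move the number beyond the scatter stays open, as does the outcome with a longer chain there.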